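This account rests on a few compounds, and the source may have more. Where it says the series, first, only, none or still open, it means among the compounds named here.

Series notes, same shared core throughout, varied only at one aromatic carbon.

Compound 1 `Cc1cc(SC(C)C)c(S(C)(=O)=O)cc1C(=O)N=C(N)N` is the reference point: in a functional assay for inhibition of sodium/hydrogen exchanger (Oryctolagus cuniculus) (on this read-out higher numbers stand for weaker inhibition and lower numbers for stronger inhibition), compound 1 gives 12 nM. Compound 2 `Cc1cc(N2CCCC(O)C2)c(S(C)(=O)=O)cc1C(=O)N=C(N)N` carries 3-hydroxypiperidin-1-yl at that carbon, and in this assay compound 2 gives 30 nM. Among the measured compounds shown here, the single step so far, a 2.5-fold higher number from compound 1 to compound 2 (0.40 log units; beyond the scatter), is modest and beyond the scatter. For the measured compounds named here, compound 2 therefore stands at the highest of the two numbers measured, with compound 1 as its only neighbour.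

Compound 3 `Cc1cc(-n2ccnc2)c(S(C)(=O)=O)cc1C(=O)N=C(N)N` is the next member. Its change from compound 2 is 1H-imidazol-1-yl in place of 3-hydroxypiperidin-1-yl on an aromatic carbon. Going by the values given here, only one measured step bears on this: the exchange at the same carbon in a 2.5-fold higher number from compound 1 to compound 2 (0.40 log units; beyond the scatter), which moved the number modestly. A swap of the ring at this place is thus expected to shift this assay by a modest step at most, with the direction uncertain; the other substituent measured there, isopropylsulfanyl in compound 1, gave 12 nM, so a somewhat lower number than compound 2 is the working expectation. The estimate for compound 3 in this assay is 20 nM, within 7 nM to 60 nM, a step of a 1.5-fold lower number from compound 2 to compound 3 (0.18 log units; within the scatter).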

Compound 3, half-maximal inhibitory concentration: 23 nM
Beside the measured number, compound 3's estimate is 1.2-fold (0.06 log units) below it; low and high end bracket the measured number.
By their numbers in this assay, from the lowest: compounds 1, 3 and 2 (each within the scatter of the next, the first and the last beyond it).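

In this assay, 1H-imidazol-1-yl in place of 3-hydroxypiperidin-1-yl gives a 1.3-fold lower number from compound 2 to compound 3 (0.12 log units; within the scatter), so exchanging a six-membered non-aromatic ring for a five-membered aromatic ring with 2 hetero atoms does not separate these two compounds, and a hydrogen-bond donor on the group at this carbon is not required for a number in this range. Against isopropylsulfanyl, the same group gives a 1.9-fold higher number from compound 1 to compound 3 (0.28 log units; within the scatter), which leaves compound 3 within the scatter of both neighbours, although a 2.5-fold higher number from compound 1 to compound 2 (0.40 log units; beyond the scatter) is a step beyond it. At this carbon, ortho to the methylsulfonyl group, the three groups therefore differ clearly only at the two ends of the set, compound 1 and compound 2, with compound 3 not separable from either. Nothing on hand explains these steps.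

Piperidin-1-yl without the hydroxyl would show whether the hydroxyl or the ring accounts for the step between compound 1 and compound 2. Going by these compounds, how a carboxylic acid, a primary amine or a longer alkylsulfanyl chain at this carbon would read remains open.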